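Alkyl variation beside the ketone in the core series

A few compounds are considered here, and "the series" means these few. Any claim that something is new, unique, unknown or untested is made for them only; others in the source may bear on it.

Three members of the series have been measured in an assay on HEK293 cells for positive allosteric modulation of metabotropic glutamate receptor 2 (Rattus norvegicus), read by thallium flux, with a stated time of 2.5 min; a higher number here means a larger maximal response, a lower number a smaller maximal response. Compound 1 `Cc1c(OCCCCOc2ccc(C(=O)CC(C)(C)C)c(O)c2C)cccc1C(=O)O` gives 95.8%, compound 2 `Cc1c(OCCCCOc2ccccc2C(=O)O)ccc(C(=O)CC(C)C)c1O` gives 92.4%, and compound 3 `Cc1c(OCCCCOc2ccccc2C(=O)O)ccc(C(=O)CC2CCCC2)c1O` gives 98.8%. Compound 1 stands second highest of these three numbers, though both compound 3 and compound 2 lie within the scatter of it. Compound 4 `CCC(=O)c1ccc(OCCCCOc2cccc(C(=O)O)c2C)c(C)c1O` differs from compound 1 in one place: methyl in place of tert-butyl on a saturated chain carbon bound to a carbonyl carbon. Among the measured compounds shown here, the only measured step at the same place is a number 6.4 percentage points higher from compound 2 to compound 3 (within the scatter), which stays within the scatter. On that basis no step beyond the scatter is expected for compound 4 in either direction, and the expected step is a number 1.8 percentage points lower from compound 1 to compound 4 (within the scatter). Compound 4 is therefore estimated to give about 94%, with a range from 82% to 104%.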

Compound 4, largest response reached (reported as percent of maximum), in percent of the reference or control that the assay uses: 71.3%
Compound 4: the middle estimate sits 22.7 percentage points above what was measured; the whole stated range lies above it.
By their numbers in this assay, from the lowest: compound 4; then compounds 2, 1 and 3 (each within the scatter of the next).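

In this assay, among the compounds shown here, the group on a saturated chain carbon bound to a carbonyl carbon does matter: methyl in place of tert-butyl gives a number 24.5 percentage points lower from compound 1 to compound 4 (beyond the scatter) and is the first change at this place to leave the scatter. Cyclopentyl in place of isopropyl gave only a number 6.4 percentage points higher from compound 2 to compound 3 (within the scatter) and did so on a differently substituted partner, so the two steps do not share a background. No data here bear on why the response falls.

From the compounds shown here alone, whether ethyl at this place keeps the response or shares the loss remains open. Also open, going by these compounds, is whether methyl would cost as much alongside the partner of compound 2 and compound 3.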